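The compounds below may be only part of what the source reports. "The series", "measured", "known", "first", "only" and "open" are said of these compounds alone.

Compound 1, `CC1=C(C(N)=O)C(c2ccoc2)NC(=O)N1`, gives 1% in an assay on membranes from CHO cells for displacement of a labelled ligand from adenosine receptor A1 (Homo sapiens), read by scintillation counting, with a stated time of 60 min, tested at 1 uM; a higher number here means more inhibition at the concentration tested (going by the name of the read-out), a lower number less inhibition.
Compound 2, `CCNC(=O)C1=C(C)NC(=O)NC1c1ccoc1`, gives 1% in this assay.
Compound 3, `CC1=C(C(=O)SC(C)C)C(c2ccoc2)NC(=O)N1`, gives 9% in this assay.

All three compounds share one core and differ only in the group attached to a carbonyl carbon or to the amide-type nitrogen hanging from it. Compound 3 has the highest number of the three, but that says little: the gap a number 8 percentage points higher from compound 1 to compound 3 (within the scatter) and the gap a number 8 percentage points higher from compound 2 to compound 3 (within the scatter) both lie within the scatter of repeated measurements, as does no change at the digits printed from compound 1 to compound 2 (within the scatter). The numbers of the three compounds are level in this assay.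

Compound 4, `CC1=C(c2ncc(C)o2)C(c2ccoc2)NC(=O)N1`, changes that same position more deeply: 5-methyl-1,3-oxazol-2-yl in place of (isopropylsulfanyl)carbonyl on a double-bonded ring carbon. Here the carbonyl group itself is gone and a five-membered aromatic ring takes its place, so no measured step covers this kind of exchange directly. What the measured steps do show is that three different groups at this position all left the number low and within the scatter of each other. The step of a number 3 percentage points lower from compound 3 to compound 4 (within the scatter) is therefore expected to stay within the scatter as well. Compound 4 is expected to give about 6%, somewhere between 0% and 22%.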

Compound 4, a percentage reported as inhibition, at one concentration (the size of the read-out at that concentration, not a potency): 21%
Estimate against measurement, compound 4: 15 percentage points below; measured number inside the range.
By their numbers in this assay, from the lowest: compounds 1, 2 and 3 (each within the scatter of the next); then compound 4.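

In this assay this position now shows a real response, with a number 12 percentage points higher from compound 3 to compound 4 (beyond the scatter) and a number 20 percentage points higher from compound 2 to compound 4 (beyond the scatter) and also a number 20 percentage points higher from compound 1 to compound 4 (beyond the scatter) for the exchange of each carbonyl-linked group for 5-methyl-1,3-oxazol-2-yl. For the compounds shown here, the three carbonyl-linked groups on this double-bonded ring carbon had left the numbers level, so the earlier compounds gave no sign that a change here could move the read-out beyond the scatter, while the three new steps all point the same way, though each is only modest. Nothing available explains why the aromatic ring behaves differently from the carbonyl-linked groups.

Since the new group differs from the old ones in several ways at once, the compounds shown cannot separate the part played by the ring itself from that of its methyl group. As far as these compounds go, whether an oxazole without the methyl group, a thiazole ring or a plain phenyl ring at this position would give a similar number stays open, as does how compound 4 would behave at concentrations other than the single one tested.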